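The source may report more compounds than this note shows. Statements on the series, on what has been measured and on what is new or still open speak of the compounds shown alone.

Of the compounds shown here, three built on one shared core have been tested in a functional assay on HeLa cells (Homo sapiens) for antiproliferative activity, read by CCK-8 assay, with a stated time of 48 h; on this read-out lower numbers stand for stronger inhibition and higher numbers for weaker inhibition. Compound 1 `CC(C)CSc1n[nH]c(-n2[se]c3ccccc3c2=O)n1` gives 34900 nM, compound 3 `CC(C)Sc1n[nH]c(-n2[se]c3ccccc3c2=O)n1` gives 34600 nM, and compound 2 `Cc1ccccc1CSc1n[nH]c(-n2[se]c3ccccc3c2=O)n1` gives 6130 nM, the lowest number of the three. The untested compound 4 `CCCCCSc1n[nH]c(-n2[se]c3ccccc3c2=O)n1` differs from compound 2 by butyl in place of 2-methylphenyl on a saturated chain carbon bound to a sulfur. For the measured compounds named here, two measured steps bear on this change: a 5.7-fold lower number from compound 1 to compound 2 (0.76 log units; beyond the scatter) and a 5.6-fold higher number from compound 2 to compound 3 (0.75 log units; beyond the scatter), while a 1.0-fold lower number from compound 1 to compound 3 (0.00 log units; within the scatter). Exchanging the 2-methylbenzyl group of compound 2 for a pentyl chain is therefore expected to raise the number, with a step of a 4.9-fold higher number from compound 2 to compound 4 (0.69 log units; beyond the scatter). Compound 4 is estimated at 30000 nM, within a range of 12000 nM to 70000 nM.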

Compound 4, half-maximal inhibitory concentration: 30300 nM
For compound 4 the middle estimate is 1.0-fold (0.00 log units) below the measured one; the measured number falls inside the stated range.
By their numbers in this assay, from the lowest: compound 2; then compounds 4, 3 and 1 (each within the scatter of the next).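

Pentyl on the sulfur gives no separation from the two shorter branched groups in this assay: there is a 1.1-fold lower number from compound 3 to compound 4 (0.06 log units; within the scatter) and a 1.2-fold lower number from compound 1 to compound 4 (0.06 log units; within the scatter), so among these three open chains, shape and length make no visible difference. For the compounds shown here, by contrast, a 4.9-fold higher number from compound 2 to compound 4 (0.69 log units; beyond the scatter) leaves compound 2, with its 2-methylbenzyl group, as the only compound here carrying a ring at this place and the only one set apart. Nothing available explains this gap. Going by these compounds, whether the ring or its methyl group matters stays open, and a plain benzyl group would separate the two. A much longer chain, such as decyl, also remains untested among the compounds shown.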